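Swapping 2-fluorophenyl for 4-nitrophenyl on the shared core

The compounds below may be only part of what the source reports. "The series", "measured", "known", "first", "only" and "open" are said of these compounds alone.

In a functional assay on MCF7 cells (Homo sapiens) for antiproliferative activity, read by MTT assay, with a stated time of 48 h (a higher number here means a weaker inhibitor, a lower number a stronger inhibitor), compound 1 `CC(=O)N1N=C(c2ccc3ccccc3c2)OC1c1ccccc1Br` gives 5.49 ug/mL and compound 2 `CC(=O)N1N=C(c2ccc3ccccc3c2)OC1c1ccccc1F` gives 3.44 ug/mL. These two values lie within the scatter of each other, so compound 2 cannot be separated from compound 1. Compound 3 `CC(=O)N1N=C(c2ccc3ccccc3c2)OC1c1ccc([N+](=O)[O-])cc1` keeps the shared core but carries 4-nitrophenyl in place of 2-fluorophenyl on a saturated ring carbon. Within the data shown here, only one measured step bears on this change, fluoro in place of bromo on an aromatic carbon, which gave a 1.6-fold lower number from compound 1 to compound 2 (0.20 log units; within the scatter) and so stays within the scatter. Among the measured compounds shown here, no measured compound carries 4-nitrophenyl, so that step is weak guidance, and no clear shift is expected in this assay. The expected change is a 1.3-fold higher number from compound 2 to compound 3 (0.12 log units; within the scatter), which is no real move beyond the scatter. For compound 3 the estimated value is 4.5 ug/mL, with an expected range from 1.5 ug/mL to 14 ug/mL.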

Compound 3, half-maximal inhibitory concentration: 7.59 ug/mL
Beside the measured number, compound 3's estimate is 1.7-fold (0.23 log units) below it, within the range that was stated.
By their numbers in this assay, from the lowest: compounds 2, 1 and 3 (each within the scatter of the next, the first and the last beyond it).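

In this assay, among these compounds, 4-nitrophenyl in place of 2-fluorophenyl gives a 2.2-fold higher number from compound 2 to compound 3 (0.34 log units; beyond the scatter) and is the first step here to pass beyond the scatter, which shows that the group on this saturated ring carbon can move the number, though only modestly. Set against 2-bromophenyl, the same 4-nitrophenyl gives a 1.4-fold higher number from compound 1 to compound 3 (0.14 log units; within the scatter) and no separation, so the shift rests on a single pair. Nothing measured here offers an explanation for this step.

The substituent and its place on the phenyl ring both change from compound 2 to compound 3, and the compounds shown do not separate these two changes. Also open, from the compounds shown here alone, is how a plain phenyl, or a phenyl carrying an amine or a carboxylic acid, would behave at this position.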